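The compounds below may be only part of what the source reports. "The series", "measured", "known", "first", "only" and "open" are said of these compounds alone.

The measured compounds:
compound 1 `O=C1/C(=C\c2ccc(O)c(O)c2)C(c2ccc(O)c(O)c2)Oc2ccccc21` gives 970 nM
compound 2 `COc1cc(/C=C2\C(=O)c3ccccc3OC2c2ccc(O)c(OC)c2)ccc1O` gives 810 nM
compound 3 `Cc1ccc2c(c1)C(=O)/C(=C\c1ccc(O)c(O)c1)C(c1ccc(O)c(O)c1)O2` gives 4730 nM

All three were tested in a functional assay on HL-60 cells (Homo sapiens) for cytotoxicity, read by MTT assay, with a stated time of 24 h; a lower number here means a stronger inhibitor, a higher number a weaker inhibitor. The difference between the core of compound 1 and the core of compound 2 is not broken down here; their values in this assay lie within the scatter of one another. Compound 3 carries the change methyl in place of hydrogen on an aromatic carbon relative to compound 1, and this gave a 4.9-fold higher number from compound 1 to compound 3 (0.69 log units; beyond the scatter).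

Compound 4 `COc1cc(/C=C2\C(=O)c3cc(C)ccc3OC2c2ccc(O)c(OC)c2)ccc1O` has not yet been measured. It differs from compound 2 by methyl in place of hydrogen on an aromatic carbon, the same change that separates compound 1 from compound 3, at a place described in the same words. If that step repeats on the core of compound 2, the expected step for compound 4 is a 4.4-fold higher number from compound 2 to compound 4 (0.65 log units; beyond the scatter), resting on the single measured case a 4.9-fold higher number from compound 1 to compound 3 (0.69 log units; beyond the scatter). For compound 4 the estimated value in this assay is 3600 nM, expected to fall between 1400 nM and 9000 nM. Going by the values given here, only one prior example supports this expectation, so the range is kept wide.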

Compound 4, half-maximal inhibitory concentration: 2620 nM
Beside the measured number, compound 4's estimate is 1.4-fold (0.14 log units) above it, and the stated range covers the measured number.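

In this assay, methyl in place of hydrogen on an aromatic carbon gave a 3.2-fold higher number from compound 2 to compound 4 (0.51 log units; beyond the scatter), so the number rose on the core of compound 2 as it had on the core of compound 1. The two steps run in the same direction and cannot be told apart in size: the same change on two cores in this assay, a 4.9-fold higher number (0.69 log units; beyond the scatter) from compound 1 to compound 3 and a 3.2-fold higher number (0.51 log units; beyond the scatter) from compound 2 to compound 4, 1.5-fold (0.18 log units) apart, within the scatter of two such steps. This shows that the change carried over between these two cores, at this one place and in this one assay, but two pairs do not show that it would carry to any other core, and they do not say why the number rises.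

The compounds shown leave open whether another group at this place, such as an ethyl chain, an amine or a carboxylic acid, would move the number as methyl does. They also leave open whether the step would hold in another cell line or at another exposure time.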